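Cyclohexyl in place of fluorophenyl on the shared core

This account rests on a few compounds, and the source may have more. Where it says the series, first, only, none or still open, it means among the compounds named here.

Compound 1 `CN1CCC[C@@H]1Cn1nc(Cc2cccc(F)c2)c2ccccc2c1=O` is measured in an assay for binding affinity to Alpha-1A adrenergic receptor (Homo sapiens) (a lower number here means a stronger inhibitor, a higher number a weaker inhibitor), and gives 50.1 nM. Among the numbers shown it stands highest of two, though the nearest, compound 2 `O=c1c2ccccc2c(Cc2ccc(Cl)cc2)nn1C[C@H]1CCCN1CCCCCc1ccc(OCCCN2CCCCCC2)cc1` with 25.1 nM in this assay, differs from it only within the scatter, so no order between the two is claimed. Compound 3 `COC(=O)c1ccc(Cc2nn(C[C@H]3CCCN3C)c(=O)c3ccccc23)cc1` in this assay is reported only as a limit, > 1990 nM, not as a number; the limit of > 1990 nM in this assay, at which 1 of the 3 values shown sits, marks where that limit sits.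

Compound 4 `CN1CCC[C@@H]1Cn1nc(CC2CCCCC2)c2ccccc2c1=O` has not yet been measured in this assay. It differs from compound 1 in one place: cyclohexyl in place of 3-fluorophenyl on a saturated chain carbon bound to an aromatic carbon. Among the measured compounds shown here, no step between two measured compounds matches this change, so its size is open. The expectation is for a loss in this assay, of moderate size, beyond the scatter, with the step of a 3.2-fold higher number from compound 1 to compound 4 (0.50 log units; beyond the scatter). For compound 4 the estimate in this assay is 160 nM, within a range from 40 nM to 630 nM.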

Compound 4, inhibition constant: > 1990 nM
Compound 4: only a limit was reported (the forecaster's own chance of this, stated with the estimate: 15%); middle value at least 12-fold (1.09 log units) from the limit.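

In this assay, cyclohexyl in place of 3-fluorophenyl gives an at least 39-fold higher number from compound 1 to compound 4 (1.59 log units; beyond the scatter), the first step read at this position of the series, and a large one: at this place the cyclohexyl ring does not keep the binding seen with compound 1. The size of the step is only a bound, as compound 4 is reported as a limit and not as a number: the limit of > 1990 nM in this assay, at which 2 of the 4 values shown sit. The change removes the aromatic ring and the fluorine together, so this single step cannot assign the loss to either one.

Open, going by these compounds, is how plain benzyl, carrying no fluorine, would read at this place, which would separate the ring from the halogen. Also open, on these data alone, is whether an amine on the cyclohexyl ring, or a smaller ring such as cyclopentyl, would restore any binding.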